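Moving the Chlorine: Compound 2 to Compound 3

The source may report more compounds than this note shows. Statements on the series, on what has been measured and on what is new or still open speak of the compounds shown alone.

Measured in a functional assay on MGC-803 cells (Homo sapiens) for antiproliferative activity, read by MTT assay, with a stated time of 72 h; on this read-out higher numbers stand for weaker inhibition and lower numbers for stronger inhibition:
- Compound 1 `COc1ccc(-c2nc(CNc3ccc(C(=O)NO)cc3)n(-c3ccccc3)n2)cc1`: > 20000 nM
- Compound 2 `O=C(NO)c1ccc(NCc2nc(-c3cccc(Cl)c3)nn2-c2ccccc2)cc1`: 5760 nM

Compound 1 stands at > 20000 nM, which is a limit of the assay and not a number. Among the measured compounds shown here, compound 2, at 5760 nM, holds the only actual number so far. Compound 3 `O=C(NO)c1ccc(NCc2nc(-c3ccc(Cl)cc3)nn2-c2ccccc2)cc1` carries 4-chlorophenyl in place of 3-chlorophenyl on an aromatic carbon. For the measured compounds named here, the one measured step, an at least 3.4-fold lower number from compound 1 to compound 2 (0.54 log units; beyond the scatter), changed the group at this same place, but it exchanged a different pair of groups, so it offers only weak guidance. An a 1.2-fold higher number from compound 2 to compound 3 (0.08 log units; within the scatter) is expected, with no clear change beyond the scatter in this assay. For compound 3 the estimated value is 7000 nM, with an expected range of 2500 nM to 20000 nM.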

Compound 3, half-maximal inhibitory concentration: 5970 nM
Compound 3: the middle estimate sits 1.2-fold (0.07 log units) above what was measured, within the range that was stated.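

In this assay, among the compounds shown here, 4-chlorophenyl in place of 3-chlorophenyl gives a 1.0-fold higher number from compound 2 to compound 3 (0.02 log units; within the scatter), so at this position the two chlorophenyl groups cannot be told apart, something the earlier compounds could not show. Chloro in place of methoxy gives an at least 3.3-fold lower number from compound 1 to compound 3 (0.52 log units; beyond the scatter), so the lower number relative to compound 1 holds for both chlorophenyl groups. Compound 1 stands at a limit of the assay and not a number, so the full size of that step stays unknown: the limit of > 20000 nM in this assay, at which 1 of the 3 values shown sits.

The compounds shown leave open what an amine or a carboxylic acid on this phenyl ring would do to the number.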